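Extending the bromoalkoxy chain on the shared core

The source may report more compounds than this note shows. Statements on the series, on what has been measured and on what is new or still open speak of the compounds shown alone.

Measured in a functional assay on MDA-MB-231 cells (Homo sapiens) for antiproliferative activity, read by MTT assay, with a stated time of 48 h; a higher number here means a weaker inhibitor, a lower number a stronger inhibitor:
Compound 1 `COc1ccc(N(C)c2ccnc(Cl)n2)cc1Cl`: 1380 nM
Compound 2 `COc1ccc(N(C)c2ccnc(Cl)n2)cc1[N+](=O)[O-]`: 8120 nM
Compound 3 `COc1ccc(N(C)c2ccnc(Cl)n2)cc1OCCCBr`: 1280 nM

Compound 1 holds the second highest of the three numbers; compound 3 lies within the scatter of it, while compound 2 is clearly weaker, the step being a 5.9-fold higher number from compound 1 to compound 2 (0.77 log units; beyond the scatter).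

Compound 4 `COc1ccc(N(C)c2ccnc(Cl)n2)cc1OCCCCBr` differs from compound 1 by 4-bromobutoxy in place of chloro on an aromatic carbon. Within the data shown here, the one measured step that bears on this is a 1.1-fold lower number from compound 1 to compound 3 (0.03 log units; within the scatter), where the 3-bromopropoxy chain left the number unchanged within the scatter. The 4-bromobutoxy chain is the next homologue of the same chain, so no step beyond the scatter is expected in this assay. Compound 4 is therefore estimated at 1300 nM, with a range of 600 nM to 2800 nM, meaning an expected step of a 1.1-fold lower number from compound 1 to compound 4 (0.03 log units; within the scatter).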

Compound 4, half-maximal inhibitory concentration: 992 nM
Beside the measured number, compound 4's estimate is 1.3-fold (0.12 log units) above it; low and high end bracket the measured number.
By their numbers in this assay, from the lowest: compounds 4, 3 and 1 (each within the scatter of the next); then compound 2.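

In this assay the position tolerates the 4-bromobutoxy chain as it did the 3-bromopropoxy chain: the step to chloro reads a 1.4-fold lower number from compound 1 to compound 4 (0.14 log units; within the scatter) and the step between the two homologues reads a 1.3-fold lower number from compound 3 to compound 4 (0.11 log units; within the scatter), so the added chain carbon gives no readable change. The separation from the nitro group holds at an 8.2-fold lower number from compound 2 to compound 4 (0.91 log units; beyond the scatter), leaving compound 2 alone as the weaker outlier among the four. No measured evidence bears on the origin of these numbers.

From the compounds shown here alone, whether the terminal bromine matters remains open, as does the response to a chain ending in an amine or a hydroxyl group. Going by these compounds, a longer bromoalkoxy chain also remains untested here as a limit of this tolerance.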